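Adding Methylsulfonyl to the Phenyl Ring of Compound 3

A few compounds are considered here, and "the series" means these few. Any claim that something is new, unique, unknown or untested is made for them only; others in the source may bear on it.

For the measured compounds named here, compound 3 `COc1cc2nc(N3CCN(S(=O)(=O)c4ccc(-c5ccccc5)cc4)CC3)nc(N)c2cc1OC` gives 4200 nM in a functional assay on PC-3 cells (Homo sapiens) for inhibition (on this read-out lower numbers stand for stronger inhibition and higher numbers for weaker inhibition), the lowest of the three numbers measured so far. Compound 1 `COc1cc2nc(N3CCN(S(=O)(=O)c4ccc(C)cc4)CC3)nc(N)c2cc1OC` gives 30000 nM and compound 2 `COc1cc2nc(N3CCN(S(=O)(=O)c4ccc(C(=O)O)cc4)CC3)nc(N)c2cc1OC` gives 53000 nM; the step of a 7.1-fold lower number from compound 1 to compound 3 (0.85 log units; beyond the scatter) and the step of a 13-fold lower number from compound 2 to compound 3 (1.10 log units; beyond the scatter) both point the same way, whereas a 1.8-fold higher number from compound 1 to compound 2 (0.25 log units; within the scatter). Compound 4 `COc1cc2nc(N3CCN(S(=O)(=O)c4ccc(-c5ccc(S(C)(=O)=O)cc5)cc4)CC3)nc(N)c2cc1OC` differs from compound 3 by methylsulfonyl in place of hydrogen on an aromatic carbon. Going by the values given here, no measured step tests this exact change; the closest comparison is the swap of carboxy for methyl between compound 1 and compound 2, which stayed within the scatter. The expectation is therefore a step of a 1.1-fold lower number from compound 3 to compound 4 (0.02 log units; within the scatter), not clearly beyond the scatter in either direction. Compound 4 is estimated at 4000 nM, with a range from 1300 nM to 12000 nM.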

Compound 4, half-maximal inhibitory concentration: 7200 nM
The estimate for compound 4 lay 1.8-fold (0.26 log units) below the measured number; the measured number falls inside the stated range.
By their numbers in this assay, from the lowest: compounds 3 and 4 (each within the scatter of the next); then compounds 1 and 2 (each within the scatter of the next).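

Methylsulfonyl para to a large group on the outer phenyl ring leaves the number within the scatter (a 1.7-fold higher number from compound 3 to compound 4 (0.23 log units; within the scatter)), so this position accepts a substituent without a clear change. The 4-(methylsulfonyl)phenyl group still gives lower numbers than the smaller groups it replaces (a 4.2-fold lower number from compound 1 to compound 4 (0.62 log units; beyond the scatter); a 7.4-fold lower number from compound 2 to compound 4 (0.87 log units; beyond the scatter)). Nothing available explains these steps. Still open, as far as these compounds go, is whether an amine or a carboxylic acid at this same position would also stay within the scatter, and whether a longer chain there would do the same.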